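From Acetyl to Chloro: What to Expect for Compound 4

This account rests on a few compounds, and the source may have more. Where it says the series, first, only, none or still open, it means among the compounds named here.

Three compounds have so far been measured in an ADME assay on the whole organism with Oryza sativa as the target, tested at 0.1 uM; on this read-out lower numbers stand for a stronger effect and higher numbers for a weaker effect at the one concentration tested:

compound 1 `CC(C)c1cccc(NC(=O)N[C@@H](C)c2ccccc2)c1` gives 95%
compound 2 `COc1cccc(NC(=O)N[C@@H](C)c2ccccc2)c1` gives 101%
compound 3 `CC(=O)c1cccc(NC(=O)N[C@@H](C)c2ccccc2)c1` gives 96%

All three share one core and differ only in a single group on an aromatic carbon. Their numbers lie close together: the step of a number 1 percentage points higher from compound 1 to compound 3 (within the scatter) and the step of a number 5 percentage points lower from compound 2 to compound 3 (within the scatter) are both within the usual scatter, so compound 3 cannot be told apart from its two neighbours on this read-out.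

Compound 4 `C[C@H](NC(=O)Nc1cccc(Cl)c1)c1ccccc1` is the next member of the series. Its change from compound 3 is chloro in place of acetyl on an aromatic carbon.

The measured steps that bear on this are the three exchanges at the same aromatic carbon: a number 6 percentage points higher from compound 1 to compound 2 (within the scatter), a number 1 percentage points higher from compound 1 to compound 3 (within the scatter) and a number 5 percentage points lower from compound 2 to compound 3 (within the scatter). Each was within the scatter, which means that swapping isopropyl, methoxy and acetyl at this position did not move the read-out by a measurable amount. Chloro has not been tried at this position, so the expectation rests on that pattern alone. Compound 4 is therefore expected to show no step beyond the scatter, with an estimated step of a number 1 percentage points higher from compound 3 to compound 4 (within the scatter). For compound 4 the estimated value is 97%, with a range from 86% to 108%.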

Compound 4, a percentage reported as activity, at one concentration (the size of the read-out at that concentration, not a potency): 103%
For compound 4 the middle estimate is 6 percentage points below the measured one; low and high end bracket the measured number.
By their numbers in this assay, from the lowest: compounds 1, 3, 2 and 4 (each within the scatter of the next).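

Chloro, with 1 heavy atom and no hydrogen-bond acceptor, replaces acetyl, with 3 heavy atoms and 1 hydrogen-bond acceptor, and even this exchange gives in this assay only a number 7 percentage points higher from compound 3 to compound 4 (within the scatter). The two other comparisons with the new compound read the same way, at a number 2 percentage points higher from compound 2 to compound 4 (within the scatter) and a number 8 percentage points higher from compound 1 to compound 4 (within the scatter), so all the exchanges among isopropyl, methoxy, acetyl and chloro at this aromatic carbon now stay within the scatter, and compound 1, compound 2, compound 3 and compound 4 cannot be told apart on this read-out. No measurement at hand explains why these four groups read alike.

From the compounds shown here alone, whether any group at this aromatic carbon can produce a step beyond the scatter stays open, since an amine, a carboxylic acid or a longer chain could behave differently from the four groups seen so far. These compounds also differ in this one place only, so they give no information on how the read-out would respond to a change elsewhere in the shared core.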